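Benzyl for 4-methylphenyl: what to expect of compound 4

The source may report more compounds than this note shows. Statements on the series, on what has been measured and on what is new or still open speak of the compounds shown alone.

Measured in a functional assay on PC-3 cells (Homo sapiens) for antiproliferative activity, read by MTT assay, with a stated time of 24 h; a higher number here means a weaker inhibitor, a lower number a stronger inhibitor:
compound 1 `O=C1O/C(=C\Cn2cc(C3=CCCCC3)nn2)C(OCc2ccccc2)=C1OCc1ccccc1`: 55600 nM
compound 2 `Cc1ccc(-c2cn(C/C=C3\OC(=O)C(OCc4ccccc4)=C3OCc3ccccc3)nn2)cc1`: its result is a limit of the assay, > 100000 nM
compound 3 `Cc1ccc(-c2cn(CCC3(O)NC(=O)C(OCc4ccccc4)=C3OCc3ccccc3)nn2)cc1`: 84200 nM

Compound 3 holds the higher of the two numbers that were read, but its nearest neighbour, compound 1, lies within the usual scatter of it, so the two cannot be ranked. The third value, that of compound 2, is only a limit of > 100000 nM in this assay, at which 1 of the 3 values shown sits, and gives no number at all.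

Compound 4 `O=C1NC(O)(CCn2cc(Cc3ccccc3)nn2)C(OCc2ccccc2)=C1OCc1ccccc1` has the same atoms as compound 3, joined differently: benzyl in place of 4-methylphenyl on an aromatic carbon. For the measured compounds named here, the only measured step at this carbon of the shared core is an at least 1.7-fold higher number from compound 1 to compound 2 (0.25 log units; that floor lies within the scatter), and even that step has a floor lying within the scatter, so it exchanges other groups than those exchanged here and tells nothing about the size or direction of the present change. All three measured compounds cluster at very weak inhibition, and nothing shown suggests that moving from 4-methylphenyl to benzyl at this position would leave that cluster.

Compound 4 is therefore expected to give about 80000 nM, with a plausible range from 35000 nM to 180000 nM. The step of a 1.1-fold lower number from compound 3 to compound 4 (0.02 log units; within the scatter) is expected to stay within the scatter.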

Compound 4, half-maximal inhibitory concentration: > 100000 nM
Compound 4 was reported as a limit; the forecaster's own chance of this, stated with the estimate: 35%; middle value at least 1.2-fold (0.09 log units) away from the limit.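

Putting benzyl in place of 4-methylphenyl on this aromatic carbon gives, in this assay, an at least 1.1-fold higher number from compound 3 to compound 4 (0.07 log units; that floor lies within the scatter). The value for compound 4 is a limit, so this step has only a floor, and that floor cannot be told apart from no change at all. What compound 4 adds is a first look at benzyl on this carbon: two groups with the same count of heavy atoms, one joined directly to the five-membered aromatic ring and one joined through an extra carbon, both leave the shared core at very weak inhibition, and the limit now restricts how many compounds can be compared by number: the limit of > 100000 nM in this assay, at which 2 of the 4 values shown sit.

The compounds shown leave open whether any group on this carbon, such as an amine, a carboxylic acid or a longer chain ending in a phenyl ring, would give a readable value well away from this weak cluster. They also leave open how benzyl would behave on the core of compound 1, which carries cyclohex-1-en-1-yl at this place.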